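A few compounds are considered here, and "the series" means these few. Any claim that something is new, unique, unknown or untested is made for them only; others in the source may bear on it.

Measured compounds:
Compound 1, `CC(=O)c1cc(CO)c(OCCCCCCC#N)cc1O`, in an assay on isolated protein for binding affinity to leukotriene B4 receptor 1 (Homo sapiens), tested at 1 uM (on this read-out higher numbers stand for more inhibition at the one concentration tested (going by the name of the read-out) and lower numbers for less inhibition), gives 8%.
Compound 2, `CCc1cc(C(C)=O)c(O)cc1OCCCC(C)(C)C(N)=O`, in this assay gives 51%.

Within the data shown here, of the two numbers known, compound 2 stands highest; its nearest neighbour is compound 1, whose number lies lower by a gap that is beyond the usual scatter of repeated measurements. Compound 2 is therefore the measured starting point for compound 3, `CCc1cc(C(C)=O)c(O)cc1OCCCCCn1cncn1`, which has not yet been tested in this assay. The change from compound 2 to compound 3 is 2-(1H-1,2,4-triazol-1-yl)ethyl in place of 1-carbamoyl-1-methylethyl on a saturated chain carbon, three bonds along the chain from an oxygen on an aromatic ring. A carbamoyl group with its hydrogen-bond donor leaves, and an aromatic five-membered ring with three nitrogen acceptors enters in the same part of the chain. Among the measured compounds shown here, no measured pair in this set carries a change of this kind, so the size of the step can only be guessed from the two numbers at hand. The expectation is a modest loss, with the step from compound 2 to compound 3 estimated at a number 11 percentage points lower from compound 2 to compound 3 (beyond the scatter), possibly not beyond the scatter. Compound 3 is expected to give about 40% in this assay, with a likely range from 15% to 65%.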

Compound 3, a percentage reported as inhibition, at one concentration (the size of the read-out at that concentration, not a potency): 30%
For compound 3 the middle estimate is 10 percentage points above the measured one; low and high end bracket the measured number.
By their numbers in this assay, from the lowest: compound 1; then compound 3; then compound 2.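

In this assay, 2-(1H-1,2,4-triazol-1-yl)ethyl in place of 1-carbamoyl-1-methylethyl, on a saturated chain carbon, three bonds along the chain from an oxygen on an aromatic ring, gives a number 21 percentage points lower from compound 2 to compound 3 (beyond the scatter), so the group at this place bears on the read-out beyond the usual scatter. The carbamoyl group is still not indispensable here: compound 3 , with a five-membered aromatic ring and no hydrogen-bond donor in the entering group, keeps 30% at the one concentration tested, which is a size of effect and not a potency. No evidence is at hand that accounts for the size of this step.

The compounds shown leave open whether the drop goes with the loss of the carbamoyl group or with the entry of the triazole ring, as this single step changes both at once; a carboxylic acid, a primary amine or an imidazole at the end of the chain would begin to separate the two. They also leave open how the length of the chain plays in, which a shorter or longer chain carrying the same triazole ring would address.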